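Swapping the Aryl Group on a Sulfonamide Nitrogen

The compounds below may be only part of what the source reports. "The series", "measured", "known", "first", "only" and "open" are said of these compounds alone.

Compound 1 `O=S(=O)(Nc1ccc(Cl)c(Cl)c1)c1ccc(-c2cnc(C3CC3)o2)cc1`: > 100000 nM
Compound 2 `O=S(=O)(Nc1ccccc1Cl)c1ccc(-c2cnc(C3CC3)o2)cc1`: > 100000 nM
Compound 3 `O=S(=O)(Nc1ccc(Br)c(Cl)c1)c1ccc(-c2cnc(C3CC3)o2)cc1`: > 100000 nM

Three compounds share one core and differ only in the aryl group attached to the sulfonamide nitrogen. All were tested in a functional assay on cells (leukaemia cell line, Homo sapiens) for inhibition, read by sulforhodamine B assay, with a stated time of 48 h; a higher number here means that more compound is tolerated, a lower number that less compound is tolerated. For compound 3 the result is a limit of the assay, not a number. The same holds for compound 1, and for compound 2, so that every value sits at the limit of > 100000 nM in this assay, at which 3 of the 3 values shown sit. The steps between them cannot be read: a step that the two limits leave unreadable from compound 1 to compound 3 and a step that the two limits leave unreadable from compound 2 to compound 3, and likewise a step that the two limits leave unreadable from compound 1 to compound 2. Compound 3 therefore stands exactly where the other two stand, at the edge of what this assay can report.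

Compound 4 `Cc1cc(F)cc(NS(=O)(=O)c2ccc(-c3cnc(C4CC4)o3)cc2)c1` is the next variation on the same theme: 3-fluoro-5-methylphenyl in place of 4-bromo-3-chlorophenyl on a sulfonamide nitrogen. It keeps the core and changes only the aryl group, as the three measured compounds do among themselves. Within the data shown here, since none of those changes produced a readable value, there is no measured step pointing to a gain or loss for compound 4. The step from compound 3 to compound 4 is expected to be a number no higher from compound 3 to compound 4 (the limit leaves the size open), with a strong chance that only a limit is reported again. Compound 4 is estimated at 100000 nM, within a range from 30000 nM to 300000 nM.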

Compound 4, concentration lethal to 50% of the cells: 78100 nM
Beside the measured number, compound 4's estimate is 1.3-fold (0.11 log units) above it; measured number inside the range.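

Compound 4 is the only one of the four shown that gives a number rather than a limit in this assay, so the aryl group on the sulfonamide nitrogen can bring a value into the range this assay reports, while the other three stay at its edge: the limit of > 100000 nM in this assay, at which 3 of the 4 values shown sit.

Set against those limits, the change reads as an at least 1.2-fold lower number from compound 3 to compound 4 (0.10 log units; that floor lies within the scatter), as an at least 1.2-fold lower number from compound 2 to compound 4 (0.10 log units; that floor lies within the scatter) and as an at least 1.2-fold lower number from compound 1 to compound 4 (0.10 log units; that floor lies within the scatter). Each of these is only a floor, so the true distance may be larger, but nothing printed yet sets compound 4 apart from the other three beyond the scatter.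

The aryl groups shown carry only halogens and a methyl, so it remains open whether a phenyl bearing an amine or a carboxylic acid, or a longer chain in place of the aryl group, would give a clearly lower number in this assay. From the compounds shown here alone, it is also open whether the fluoro or the methyl matters more, since compound 4 brings both in a single step.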